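The source may hold more compounds than are shown below. What is called first, only, known or untested is meant among the compounds shown, and "the series" means these compounds.

Measured compounds in an ADME assay on the whole organism with Oryza sativa as the target, tested at 10 uM; a lower number here means a stronger effect, a higher number a weaker effect of the compound at the concentration tested:
compound 1 `Cc1cccc(NC(=O)N[C@@H](C)c2ccccc2)c1`, 100%
compound 2 `CC(=O)c1cccc(NC(=O)N[C@H](C)c2ccccc2)c1`, 73%
compound 3 `CC(=O)c1cccc(NC(=O)N[C@@H](C)c2ccccc2)c1`, 94%

Compound 3 stands second highest of the three numbers. Its nearest neighbour is compound 1, whose value lies within the scatter of it; the furthest is compound 2, whose value lies beyond the scatter. The step of a number 6 percentage points lower from compound 1 to compound 3 (within the scatter) shows that acetyl in place of methyl on an aromatic carbon leaves the read-out within the scatter. The step of a number 21 percentage points higher from compound 2 to compound 3 (beyond the scatter) is larger, and for that pair only the fact that compounds 2 and 3 differ only in the configuration as drawn is known; it does not touch the substituent on the aromatic carbon.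

Compound 4 `C[C@H](NC(=O)Nc1cccc(I)c1)c1ccccc1` is not yet measured. It differs from compound 3 as follows: iodo in place of acetyl on an aromatic carbon. Within the data shown here, of the measured steps, only the one from compound 1 to compound 3 bears on a change at this aromatic carbon, and that step stayed within the scatter; the step between compound 2 and compound 3 concerns configuration only and does not bear on it. Among the measured compounds shown here, no measured step involves iodo. The step of no change at the digits printed from compound 3 to compound 4 (within the scatter) is therefore expected to stay within the scatter. Compound 4 is expected to give 94% in this assay, with a range from 78% to 100%.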

Compound 4, a percentage reported as activity, at one concentration (the size of the read-out at that concentration, not a potency): 93%
Compound 4: the middle estimate sits 1 percentage points above what was measured, within the range that was stated.
By their numbers in this assay, from the lowest: compound 2; then compounds 4, 3 and 1 (each within the scatter of the next).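

In this assay, methyl, acetyl and iodo now all stand on this aromatic carbon in the same configuration as drawn, and the read-out does not separate them: the record gives a number 1 percentage points lower from compound 3 to compound 4 (within the scatter) and a number 7 percentage points lower from compound 1 to compound 4 (within the scatter). The change from acetyl to iodo replaces three heavy atoms, a double bond outside aromatic rings and a hydrogen-bond acceptor with a single iodine atom, on a carbon meta to a large group, and even an exchange of this size leaves the number within the scatter. No measurement at hand explains this flat result, and what is known about compounds 2 and 3 concerns configuration, not this substituent.

On these data alone, whether an amine, a carboxylic acid or a longer chain on this aromatic carbon would move the number beyond the scatter stays open. Also open, as far as these compounds go, is whether the difference in configuration seen with acetyl would hold with iodo or methyl, as the configuration drawn in compound 2 appears here only with acetyl.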